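Removing the pyrazole from compound 2: permeability outlook

The source may report more compounds than this note shows. Statements on the series, on what has been measured and on what is new or still open speak of the compounds shown alone.

Measured so far in an ADME assay on Caco-2 cells (Homo sapiens) for permeability; a lower number here means that the compound crosses the layer more slowly, a higher number that the compound crosses the layer faster:
compound 1 `Cc1n[nH]c(C)c1-c1cncc(-c2ccc(C(N)=O)c(OC(C)C)c2)c1`: 41 10^-6 cm/s
compound 2 `Cc1c(-c2cncc(-c3ccc(C(N)=O)c(OC(C)C)c3)c2)cnn1C`: 21 10^-6 cm/s

Compound 2 gives the lowest of the two numbers; its nearest neighbour is compound 1, and the step of a 2.0-fold lower number from compound 1 to compound 2 (0.29 log units; within the scatter) lies within the scatter, so the two are not distinguished by this assay.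

Compound 3 `CC(C)Oc1cc(-c2cccnc2)ccc1C(N)=O` remains to be measured. It differs from compound 2 as follows: hydrogen in place of 1,5-dimethyl-1H-pyrazol-4-yl on an aromatic carbon. Going by the values given here, no measured step of this kind exists; the only step available, a 2.0-fold lower number from compound 1 to compound 2 (0.29 log units; within the scatter), concerns the swap of one dimethylpyrazolyl for another and does not bear on removal of the group. Compound 3 is therefore expected to stay close to compound 2, with a 1.7-fold higher number from compound 2 to compound 3 (0.22 log units; within the scatter) as the estimated step and a wide range. The estimate for compound 3 in this assay is 35 10^-6 cm/s, between 15 10^-6 cm/s and 70 10^-6 cm/s.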

Compound 3, apparent permeability: 20 10^-6 cm/s
Estimate against measurement, compound 3: 1.8-fold (0.24 log units) above, within the range that was stated.
By their numbers in this assay, from the lowest: compounds 3, 2 and 1 (each within the scatter of the next, the first and the last beyond it).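

In this assay, hydrogen in place of the 1,5-dimethyl-1H-pyrazol-4-yl group gives a 1.1-fold lower number from compound 2 to compound 3 (0.02 log units; within the scatter), so at this aromatic carbon the whole five-membered ring can go without compound 2 and compound 3 being distinguished by this read-out. The same removal of the isomeric 3,5-dimethyl-1H-pyrazol-4-yl group gives a 2.1-fold lower number from compound 1 to compound 3 (0.31 log units; beyond the scatter), a modest step and the only one among these three compounds that lies beyond the scatter. Nothing available accounts for either step.

Open, on these data alone, is how an amine, a carboxylic acid or a morpholine at this aromatic carbon would read in this assay. Also open, as far as these compounds go, is whether a single methyl or a longer chain there would stay within the scatter of compound 3.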